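Methyl in place of methoxy: compound 2 to compound 3

The compounds below may be only part of what the source reports. "The series", "measured", "known", "first", "only" and "open" are said of these compounds alone.

Among the compounds with values here, in an assay on isolated protein for inhibition of tyrosine-protein kinase Mer (Homo sapiens), read by LC-MS (a lower number here means a stronger inhibitor, a higher number a weaker inhibitor), compound 2 `COc1ccccc1-c1ccc(-c2nnc(N(C)Cc3ccc4nccn4c3)o2)cc1` gives 31.6 nM, the lowest of the two numbers so far. Within the data shown here, compound 1 `CN(Cc1ccc2nccn2c1)c1nnc(-c2ccc(C3CC3)cc2)o1` gives 794 nM, and the only measured step, a 25-fold lower number from compound 1 to compound 2 (1.40 log units; beyond the scatter), swaps the whole group on the core. Compound 3 `Cc1ccccc1-c1ccc(-c2nnc(N(C)Cc3ccc4nccn4c3)o2)cc1` differs from compound 2 by methyl in place of methoxy on an aromatic carbon. Among the measured compounds shown here, no measured step touches that position, so the size of a methoxy-to-methyl exchange cannot be read from the data; the large step elsewhere does not bear on it. The expected step is small, a 1.6-fold higher number from compound 2 to compound 3 (0.20 log units; within the scatter), within or just beyond the scatter. Compound 3 is estimated at 50 nM, between 15 nM and 160 nM.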

Compound 3, half-maximal inhibitory concentration: 12.6 nM
The estimate for compound 3 lay 4.0-fold (0.60 log units) above the measured number; measured number below the stated range.
By their numbers in this assay, from the lowest: compound 3; then compound 2; then compound 1.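

In this assay methyl in place of methoxy brings a 2.5-fold lower number from compound 2 to compound 3 (0.40 log units; beyond the scatter) on an aromatic carbon ortho to a large group, so the oxygen and its hydrogen-bond acceptor are not required for a low number at this place. 2-methylphenyl in place of cyclopropyl brings a 63-fold lower number from compound 1 to compound 3 (1.80 log units; beyond the scatter) and so goes further than 2-methoxyphenyl did. No available evidence bears on the reason for this difference. Open, from the compounds shown here alone, is whether ethyl, chlorine or an amine at this place would go lower than methyl. Also open, going by these compounds, is how a plain phenyl, with only hydrogen there, would compare with compound 3.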